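The compounds below may be only part of what the source reports. "The series", "measured", "known", "first", "only" and "open" are said of these compounds alone.

Compound 1 `CN(CC1CC1)CC1(O)CCN(CCCc2c[nH]c3ccc(-n4cnnc4)cc23)CC1` gives 27 nM in an assay on CHO cells with 5-hydroxytryptamine receptor 1B (Homo sapiens) as the target; a lower number here means a stronger inhibitor, a higher number a weaker inhibitor. Among the compounds with values here, compound 2 `CC(C)(C)OC(=O)NCC1(O)CCN(CCCc2c[nH]c3ccc(-n4cnnc4)cc23)CC1` gives 340 nM in this assay, the higher of the two numbers measured so far, with a 13-fold higher number from compound 1 to compound 2 (1.10 log units; beyond the scatter) as its only neighbour. Compound 3 `CN(Cc1ccccc1)CC1(O)CCN(CCCc2c[nH]c3ccc(-n4cnnc4)cc23)CC1` carries benzyl(methyl)amino in place of (tert-butoxycarbonyl)amino on a saturated chain carbon bound to a saturated ring carbon. Within the data shown here, the one step that bears on this, a 13-fold higher number from compound 1 to compound 2 (1.10 log units; beyond the scatter), ran the other way: exchanging a tertiary amine for the carbamate cost potency heavily. Restoring a tertiary amine is therefore expected to recover most of that loss, and a step of an 11-fold lower number from compound 2 to compound 3 (1.05 log units; beyond the scatter) is estimated for compound 3. In this assay compound 3 is expected to give about 30 nM, within 10 nM to 100 nM.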

Compound 3, half-maximal inhibitory concentration: 96 nM
Compound 3: the middle estimate sits 3.2-fold (0.51 log units) below what was measured; measured number inside the range.
By their numbers in this assay, from the lowest: compound 1; then compound 3; then compound 2.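

In this assay, benzyl(methyl)amino in place of (tert-butoxycarbonyl)amino gives a 3.5-fold lower number from compound 2 to compound 3 (0.55 log units; beyond the scatter) and so regains only part of the ground lost in a 13-fold higher number from compound 1 to compound 2 (1.10 log units; beyond the scatter) at this position. A basic-looking amine label alone therefore does not set the number here: with the nitrogen and its methyl kept, phenyl in place of cyclopropyl gives a 3.6-fold higher number from compound 1 to compound 3 (0.55 log units; beyond the scatter) and the substituent on that nitrogen still counts. Nothing on hand explains either step. Open, on these data alone, is whether ring type or substituent size drives that last step; a cyclohexylmethyl group on the same nitrogen would separate the two.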